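The source may report more compounds than this note shows. Statements on the series, on what has been measured and on what is new or still open speak of the compounds shown alone.

The series shares one core, shown in compound 1 `COc1ccc(/C=C\C(=O)O)c(OCc2cn(-c3ccccc3C(=O)N3CCC(O)C3)nn2)c1CC=C(C)C`. In a functional assay on COLO 205 cells (Homo sapiens) for cytotoxicity, read by MTT assay, with a stated time of 24 h (a higher number here means a weaker inhibitor, a lower number a stronger inhibitor), compound 1 gives 25400 nM. Compound 2 `COc1ccc(/C=C\C(=O)O)c(OCc2cn(-c3ccccc3I)nn2)c1CC=C(C)C` carries an iodine on the phenyl ring attached to the triazole; in this assay compound 2 gives "not determined" (no result reported), that is, no result. Compound 3 `COc1ccc(-n2cc(COc3c(/C=C\C(=O)O)ccc(OC)c3CC=C(C)C)nn2)cc1` has a methoxy on that phenyl ring; in this assay compound 3 likewise gives "not determined" (no result reported), and compound 3 thus stands without any number, with compound 2 as the one other entry in the same position. Compound 4 `COc1ccc(/C=C\C(=O)O)c(OCc2cn(-c3ccccc3)nn2)c1CC=C(C)C` is compound 3 with hydrogen in place of methoxy on an aromatic carbon.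

For the measured compounds named here, no value is recorded for compound 3, and no step between measured compounds is available. There is no basis for expecting a step of any particular size or direction in this assay on going from compound 3 to compound 4. Nothing beyond the usual scatter is expected, and the weak value of compound 1 25400 nM is the only anchor. Compound 4 is therefore expected to come out near 30000 nM, somewhere between 8000 nM and 100000 nM.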

Compound 4, half-maximal inhibitory concentration: 32300 nM
The estimate for compound 4 lay 1.1-fold (0.03 log units) below the measured number, and the stated range covers the measured number.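

For the compounds shown here, the new value gives the first comparison at this aromatic ring: in this assay the step reads a 1.3-fold higher number from compound 1 to compound 4 (0.10 log units; within the scatter) with hydrogen in place of (3-hydroxypyrrolidin-1-yl)carbonyl on an aromatic carbon. The two compounds therefore cannot be told apart in this read-out, so removing that substituent leaves the number within the scatter. No available evidence offers an explanation for this result.

From the compounds shown here alone, the steps to compound 2 and compound 3 cannot be read, as neither compound has a number, so what iodine or methoxy does on this ring remains unknown. Whether an amine or a longer alkyl chain on this ring would shift the number beyond the scatter is also left open.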